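Pyridinyl Amide Replaces Trifluoromethylphenyl in Allosteric Modulator Series

The source may hold more compounds than are shown below. What is called first, only, known or untested is meant among the compounds shown, and "the series" means these compounds.

Compound 1 `O=C(Nc1cc(-c2ccccc2)nn1-c1ccccc1)c1ccc(OC(F)(F)F)cc1`: 18 nM
Compound 2 `O=C(Nc1cc(-c2ccccc2)nn1-c1ccccc1)c1ccc(C(F)(F)F)cc1`: 38 nM

The two measured compounds share a core and differ only in the group on the carbonyl carbon. In a functional assay on cells for positive allosteric modulation of metabotropic glutamate receptor 5 (Rattus norvegicus), read by calcium flux (on this read-out lower numbers stand for an effect already at smaller amounts and higher numbers for an effect only at larger amounts of compound), compound 1 gives 18 nM, and compound 2 gives 38 nM. Within the data shown here, the one measured step is a 2.1-fold higher number from compound 1 to compound 2 (0.32 log units; beyond the scatter), so compound 2 stands as the higher of the two numbers, with compound 1 as its only neighbour.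

Compound 3 `O=C(Nc1cc(-c2ccccc2)nn1-c1ccccc1)c1ccncc1` is not yet measured. It differs from compound 2 as follows: pyridin-4-yl in place of 4-(trifluoromethyl)phenyl on a carbonyl carbon. Among the measured compounds shown here, no measured step bears directly on this change; the single step in hand concerns an exchange of one fluorinated group for another on the aromatic ring, not the exchange of the whole ring for a heteroaromatic one. The change is therefore larger than anything the two measured compounds span. On that basis a higher number is expected for compound 3 in this assay, with wide uncertainty, the estimated step being a 3.9-fold higher number from compound 2 to compound 3 (0.60 log units; beyond the scatter). Compound 3 is thus estimated at 150 nM, within 30 nM to 1000 nM.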

Compound 3, half-maximal effective concentration: 2500 nM
For compound 3 the middle estimate is 17-fold (1.22 log units) below the measured one; measured number above the stated range.
By their numbers in this assay, from the lowest: compound 1; then compound 2; then compound 3.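

In this assay the exchange of 4-(trifluoromethyl)phenyl for pyridin-4-yl on the carbonyl carbon gives a 66-fold higher number from compound 2 to compound 3 (1.82 log units; beyond the scatter) and so marks a large step, whereas the exchange of one fluorinated group for another on the aromatic ring had been modest (a 2.1-fold higher number from compound 1 to compound 2 (0.32 log units; beyond the scatter)). The result shows that this position, on a carbonyl carbon whose other neighbour is an amide-type nitrogen, is far more sensitive to replacing the whole ring than the earlier pair could reveal, and that a six-membered aromatic ring alone does not keep the number low. Nothing available explains the size of this step.

Compound 3 loses the trifluoromethyl group and gains a ring nitrogen in a single change, so the compounds shown do not say how much of the step belongs to each. A plain phenyl on the carbonyl carbon, or a pyridin-4-yl ring carrying a trifluoromethyl group, would separate the two parts of the change.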